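The source may report more compounds than this note shows. Statements on the series, on what has been measured and on what is new or still open speak of the compounds shown alone.

Measured so far, in an assay on isolated protein for displacement of a labelled ligand from metabotropic glutamate receptor 5 (Homo sapiens), with a stated time of 60 min, tested at 1 uM; a lower number here means less inhibition, a higher number more inhibition at the concentration tested (going by the name of the read-out):

- compound 1 `COc1ccc(S(=O)(=O)c2cnc3ccc(C)cc3c2N2CCC(C)CC2)cc1Cl` gives 93%
- compound 2 `COc1ccc(S(=O)(=O)c2cnc3cc(F)ccc3c2N2CCC(C)CC2)cc1` gives 90%

Compound 2 holds the lower of the two numbers, and compound 1 stands within the scatter of it, so no order between them is claimed. Both sit high in this assay.

Compound 3 `CC1CCN(c2c(S(=O)(=O)c3ccc(F)c(F)c3)cnc3cc(F)ccc23)CC1` differs from compound 2 by 3,4-difluorophenyl in place of 4-methoxyphenyl on a sulfonyl sulfur. Within the data shown here, no measured pair shows what such a change does, so the expectation rests on compound 2 alone. The expected step is a number 6 percentage points lower from compound 2 to compound 3 (within the scatter), a modest move that may well stay within the scatter, downward if anything. Compound 3 is estimated at 84%, with a range of 62% to 97%.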

Compound 3, a percentage reported as inhibition, at one concentration (the size of the read-out at that concentration, not a potency): 94%
Compound 3: the middle estimate sits 10 percentage points below what was measured; measured number inside the range.
By their numbers in this assay, from the lowest: compounds 2, 1 and 3 (each within the scatter of the next).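

Swapping 4-methoxyphenyl for 3,4-difluorophenyl on the sulfonyl sulfur gives a number 4 percentage points higher from compound 2 to compound 3 (within the scatter) in this assay. Among these compounds, this is the first matched pair, and it shows that the read-out stays high with either aryl group at this position, even though the entering group carries no hydrogen-bond acceptor. No evidence bears on why this step is so small.

As far as these compounds go, whether an amine, a carboxylic acid or a saturated ring such as cyclohexyl at this position would keep the read-out this high remains open. The percentages at one concentration also leave any potency differences among these compounds unresolved.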